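Chloro to fluoro on the pendant aryl ring

The source may hold more compounds than are shown below. What is called first, only, known or untested is meant among the compounds shown, and "the series" means these compounds.

Measured so far:
compound 1 `Cc1ccc(N2C(=O)COc3ccc(-c4cnc5ccccc5c4)cc32)cc1` — > 40000 nM
compound 2 `COc1ccc(N2C(=O)COc3ccc(-c4ccc(O)cc4)cc32)cc1` — 17300 nM
compound 3 `O=C1COc2ccc(-c3cnc4ccccc4c3)cc2N1c1ccc(Cl)cc1` — > 40000 nM

In a functional assay on MCF7 cells (Homo sapiens) for antiproliferative activity, read by MTT assay, with a stated time of 72 h (a higher number here means a weaker inhibitor, a lower number a stronger inhibitor), compound 1 gives only a limit, > 40000 nM. Compound 3 likewise gives only a limit, > 40000 nM. Within the data shown here, compound 2 is the one member with a number, 17300 nM, and it carries a different pendant group from compound 1 and compound 3, so its value is not a step to either of them. Among the measured compounds shown here, the one measured step, a step that the two limits leave unreadable from compound 1 to compound 3, cannot be sized because both ends sit at the limit of > 40000 nM in this assay, at which 2 of the 3 values shown sit. Compound 3 therefore stands at the ceiling of this assay, with one further compound beside it at the same limit.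

Compound 4 `O=C1COc2ccc(-c3cnc4ccccc4c3)cc2N1c1ccc(F)cc1` differs from compound 3 in a single place: fluoro in place of chloro on an aromatic carbon. For the measured compounds named here, no measured step involves a fluoro group, and the only halogen step on this ring is unreadable. The step of a number no higher from compound 3 to compound 4 (the limit leaves the size open) is thus expected to stay within the scatter, with the value most likely again a limit. Compound 4 is estimated at 40000 nM, in the range 15000 nM to 100000 nM.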

Compound 4, half-maximal inhibitory concentration: > 40000 nM
Compound 4 was reported as a limit (the forecaster's own chance of this, stated with the estimate: 65%); the middle value lies on the limit itself.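

Compound 1, compound 3 and compound 4 all give only a limit, so the steps among these three compounds cannot be read: the limit of > 40000 nM in this assay, at which 3 of the 4 values shown sit.

Going by these compounds, whether methyl, chloro and fluoro at this place on the pendant aryl ring differ in their effect at all stays open.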